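Swapping the Amide Nitrogen Substituent: Aromatic Ring to Oxetane

A few compounds are considered here, and "the series" means these few. Any claim that something is new, unique, unknown or untested is made for them only; others in the source may bear on it.

Measured so far in an assay on HEK293 cells for agonist activity at transient receptor potential cation channel subfamily M member 8 (Homo sapiens), read by fluorescence and calcium flux, with a stated time of 15 min; on this read-out higher numbers stand for an effect only at larger amounts of compound and lower numbers for an effect already at smaller amounts:
Compound 1 `Cc1ccc(OCC(=O)N(Cc2cccs2)c2cccnc2)cc1` gives 198 nM.
Compound 2 `Cc1ccc(OCC(=O)N(Cc2cccs2)CC(C)C)cc1` gives 900 nM.
Compound 3 `Cc1ccc(OCC(=O)N(Cc2cccs2)c2ccccn2)cc1` gives 200 nM.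

Compound 3 sits second highest of the three numbers. Its value and that of compound 1 lie within the scatter of each other, as shown by a 1.0-fold higher number from compound 1 to compound 3 (0.00 log units; within the scatter), so no order between them can be claimed; compound 2 stands apart, with a 4.5-fold lower number from compound 2 to compound 3 (0.65 log units; beyond the scatter).

Compound 4 `Cc1ccc(OCC(=O)N(Cc2cccs2)C2COC2)cc1` differs from compound 3 in one place: oxetan-3-yl in place of pyridin-2-yl on an amide-type nitrogen. The measured steps that speak to this change are those at the same nitrogen. Exchanging one six-membered aromatic ring for another left the number unchanged, a 1.0-fold higher number from compound 1 to compound 3 (0.00 log units; within the scatter). Moving from an aromatic ring to a saturated chain cost potency modestly, a 4.5-fold higher number from compound 1 to compound 2 (0.66 log units; beyond the scatter) and a 4.5-fold lower number from compound 2 to compound 3 (0.65 log units; beyond the scatter). Within the data shown here, the oxetan-3-yl group is saturated and small, and no measured compound carries a saturated ring here, so the expectation rests on the isobutyl comparison alone. A modest rise in the number is therefore expected, a 3.0-fold higher number from compound 3 to compound 4 (0.48 log units; beyond the scatter). Compound 4 is estimated at 600 nM, within a range from 200 nM to 2000 nM.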

Compound 4, half-maximal effective concentration: 23000 nM
Beside the measured number, compound 4's estimate is 38-fold (1.58 log units) below it; measured number outside the range, above it.
By their numbers in this assay, from the lowest: compounds 1 and 3 (each within the scatter of the next); then compound 2; then compound 4.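

In this assay, oxetan-3-yl on the amide-type nitrogen raises the number far more than the earlier isobutyl group did, both against pyridin-2-yl (a 120-fold higher number from compound 3 to compound 4 (2.06 log units; beyond the scatter)) and against pyridin-3-yl (a 120-fold higher number from compound 1 to compound 4 (2.07 log units; beyond the scatter)). Isobutyl and oxetan-3-yl are both non-aromatic, yet a large step separates them (a 26-fold higher number from compound 2 to compound 4 (1.41 log units; beyond the scatter)), so among these compounds, leaving out an aromatic ring at this nitrogen has no single fixed cost, and the particular non-aromatic group matters a great deal. No measurement shown here explains why this four-membered ring with its oxygen does so much worse than the open chain.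

The compounds shown leave open whether the high number goes with the oxygen or with the four-membered ring itself, a question that cyclobutyl, the same ring with carbon in place of the oxygen, would help to settle. They also leave open how a larger saturated ring such as cyclohexyl or tetrahydropyran-4-yl would compare with isobutyl and with the two pyridine groups at this nitrogen.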